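Swapping the five-membered ring for 2-fluorophenyl

The compounds below may be only part of what the source reports. "The series", "measured", "known", "first", "only" and "open" are said of these compounds alone.

Values in an ADME assay on MT4 cells (Homo sapiens) for cytotoxicity, read by MTT assay, with a stated time of 5 days (a lower number here means that less compound is tolerated, a higher number that more compound is tolerated), so far:
- compound 1 `Cc1cc(C)cc(S(=O)(=O)c2c(C(=O)N[C@@H]3CCN(Cc4ccccc4F)C3)[nH]c3ccc(Cl)cc23)c1` gives > 231000 nM (a limit of the assay)
- compound 2 `Cc1cc(C)cc(S(=O)(=O)c2c(C(=O)N[C@H]3CCN(Cc4cccnc4)C3)[nH]c3ccc(Cl)cc23)c1` gives 22800 nM (a number)
- compound 3 `Cc1cc(C)cc(S(=O)(=O)c2c(C(=O)N[C@H]3CCN(Cc4n[nH]c(=O)n4C)C3)[nH]c3ccc(Cl)cc23)c1` gives 21500 nM (a number)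

For the measured compounds named here, compound 3 and compound 2 lie within the scatter of each other, so compound 3 stands level with the only other numerical value. Not yet measured is compound 4 `Cc1cc(C)cc(S(=O)(=O)c2c(C(=O)N[C@H]3CCN(Cc4ccccc4F)C3)[nH]c3ccc(Cl)cc23)c1` and the change to it is a group of 7 heavy atoms (6 carbon, 1 fluorine; one six-membered aromatic ring of carbon only) in place of a group of 7 heavy atoms (3 carbon, 3 nitrogen, 1 oxygen; one five-membered aromatic ring with 3 hetero atoms), on a saturated chain carbon bound to an amine nitrogen in a ring as counted. Going by the values given here, one measured step bears directly on this place: a 1.1-fold lower number from compound 2 to compound 3 (0.03 log units; within the scatter) for an exchange of one aromatic group for another. Compound 1, which also carries 2-fluorophenyl, stands at the limit of > 231000 nM in this assay, at which 1 of the 3 values shown sits, and this is a limit, not a number. It leaves some room upward, so the estimate leans slightly that way. No step beyond the scatter is expected, and the expected step is a 1.4-fold higher number from compound 3 to compound 4 (0.14 log units; within the scatter) in this assay as the working figure. For compound 4 the estimated value is 30000 nM with an expected range from 12000 nM to 150000 nM in this assay.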

Compound 4, half-maximal cytotoxic concentration: 215000 nM
Compound 4: middle estimate off by 7.2-fold (0.86 log units), on the low side, outside the stated range (above it).
By their numbers in this assay, from the lowest: compounds 3 and 2 (each within the scatter of the next); then compound 4. At a limit, above all of these: compound 1.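

In this assay, 2-fluorophenyl on a saturated chain carbon bound to an amine nitrogen in a ring stands apart from both groups with ring hetero atoms: a 10-fold higher number from compound 3 to compound 4 (1.00 log units; beyond the scatter), and a 9.4-fold higher number from compound 2 to compound 4 (0.97 log units; beyond the scatter). The earlier exchange between those two groups, a 1.1-fold lower number from compound 2 to compound 3 (0.03 log units; within the scatter), gave no sign that this place responds to the group it carries, whereas these steps show that it can. The pair differing only in configuration shows an at least 1.0-fold lower number from compound 1 to compound 4 (0.03 log units; that floor lies within the scatter), a floor from which no effect of configuration can be read: the fact that compounds 1 and 4 differ only in the configuration as drawn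

In this assay, from the compounds shown here alone, compound 1 gives > 231000 nM, which is a limit and not a number, so the size of any difference from configuration stays open. Also open, going by these compounds, is whether the higher number goes with the fluorine or with the carbon-only ring, a question that plain phenyl would address, while an amine or a carboxylic acid on that ring would probe the place further.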